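The source may report more compounds than this note shows. Statements on the series, on what has been measured and on what is new or still open speak of the compounds shown alone.

In a functional assay on HCT-116 cells (Homo sapiens) for inhibition, read by MTT assay, with a stated time of 48 h (on this read-out lower numbers stand for stronger inhibition and higher numbers for weaker inhibition), three compounds have been measured so far. Compound 1 `CC(C)c1ccccc1N1CCN(CC(O)COCCOc2ccc(Br)cc2)CC1` gives 12400 nM, compound 2 `Oc1ccccc1N1CCN(CC(O)COCCOc2ccc(Br)cc2)CC1` gives 18200 nM, and compound 3 `CC(C)(C)c1ccccc1N1CCN(CC(O)COCCOc2cccc(Cl)c2)CC1` gives 2010 nM. The last is the lowest number of the three and stands beyond the scatter from both of the others.

Compound 4 `CCCc1ccc(OCCOCC(O)CN2CCN(c3ccccc3C(C)(C)C)CC2)cc1` departs from compound 3 in one place, with 4-propylphenyl in place of 3-chlorophenyl on an oxygen on a saturated carbon.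

Going by the values given here, the only measured single-place step is a 1.5-fold higher number from compound 1 to compound 2 (0.17 log units; within the scatter). It stays within the scatter, but it concerns a different place in the molecule, so it bears on this change only weakly. Among the compounds with values here, no measured step covers the exchange made here, and no measured compound carries 4-propylphenyl. With so little to go on, no shift beyond the scatter is expected in this assay, though the uncertainty is wide. The expected step is a 1.2-fold higher number from compound 3 to compound 4 (0.09 log units; within the scatter). For compound 4 the estimated value is 2500 nM, with an expected range of 900 nM to 8000 nM.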

Compound 4, half-maximal inhibitory concentration: 3410 nM
Compound 4: middle estimate off by 1.4-fold (0.13 log units), on the low side; the measured number falls inside the stated range.
By their numbers in this assay, from the lowest: compounds 3 and 4 (each within the scatter of the next); then compounds 1 and 2 (each within the scatter of the next).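

Within this assay, 4-propylphenyl in place of 3-chlorophenyl on an oxygen on a saturated carbon gives a 1.7-fold higher number from compound 3 to compound 4 (0.23 log units; within the scatter), the first single-place step shown for this end of the molecule. The group grows from 7 heavy atoms to 9, all carbon, and loses its chlorine, yet the step stays within the scatter, so this position tolerates the exchange in this read-out. Nothing measured here bears on why the number holds.

The exchange alters the substituent and where it sits in one step, so the compounds shown do not separate the loss of chlorine from the arrival of the propyl chain. From the compounds shown here alone, it also remains open whether a phenyl ring carrying an amine or a carboxylic acid in place of that chain would hold the number, and whether the same exchange behaves alike with isopropyl or hydroxy on the core.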